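From Bromophenyl to Dimethoxyphenyl on a Shared Nucleoside Core

A few compounds are considered here, and "the series" means these few. Any claim that something is new, unique, unknown or untested is made for them only; others in the source may bear on it.

Of the compounds shown here, three built on one shared core have been measured in a functional assay on K562 cells (Homo sapiens) for antiproliferative activity, with a stated time of 72 h; a lower number here means a stronger inhibitor, a higher number a weaker inhibitor. Compound 1 `OC[C@H]1O[C@@H](n2cnc3c(NCc4cccc(F)c4)ncnc32)[C@H](O)[C@@H]1O` gives 7600 nM in this assay. Compound 2 `OC[C@H]1O[C@@H](n2cnc3c(NCc4ccc(Br)cc4)ncnc32)[C@H](O)[C@@H]1O` gives 68200 nM in this assay, the highest of the two plain numbers, separated from its nearest neighbour by a 9.0-fold higher number from compound 1 to compound 2 (0.95 log units; beyond the scatter). Compound 3 `COc1cccc(CNc2ncnc3c2ncn3[C@@H]2O[C@H](CO)[C@@H](O)[C@H]2O)c1` is reported in this assay only as a limit, > 166000 nM. That limit, (the limit of > 166000 nM in this assay, at which 1 of the 3 values shown sits), means the steps of an at least 21-fold higher number from compound 1 to compound 3 (1.33 log units; beyond the scatter) and an at least 2.4-fold higher number from compound 2 to compound 3 (0.38 log units; beyond the scatter) are known only as lower bounds.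

Compound 4 `COc1cc(CNc2ncnc3c2ncn3[C@@H]2O[C@H](CO)[C@@H](O)[C@H]2O)cc(OC)c1` has not yet been measured in this assay. Relative to compound 2 the change is 3,5-dimethoxyphenyl in place of 4-bromophenyl on a saturated chain carbon bound to a nitrogen on an aromatic ring. Among the measured compounds shown here, the steps that bear on it are the two that lead into compound 3, where a methoxy-bearing phenyl already pushed the number to the limit: an at least modest rise from compound 2 and a large rise from compound 1. A second methoxy on the same ring gives no measured reason to expect a reversal. Compound 4 is therefore expected to lie around 200000 nM in this assay, with a range from 70000 nM to 600000 nM, most likely reported again only as a limit. The expected step is estimated as a 2.9-fold higher number from compound 2 to compound 4 (0.47 log units; beyond the scatter).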

Compound 4, half-maximal inhibitory concentration: > 166000 nM
Compound 4 was reported as a limit (the forecaster's own chance of this, stated with the estimate: 70%); the middle value does not contradict the limit.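

In this assay compound 4 gives > 166000 nM, which is a limit and not a number, and it joins compound 3 at that same limit: the limit of > 166000 nM in this assay, at which 2 of the 4 values shown sit.

The 3,5-dimethoxyphenyl group thus gives an at least 2.4-fold higher number from compound 2 to compound 4 (0.38 log units; beyond the scatter) and an at least 21-fold higher number from compound 1 to compound 4 (1.33 log units; beyond the scatter), so a second methoxy on the ring did not restore a plain number, and among the four compounds shown, only those carrying a single halogen on the ring, compound 1 and compound 2, have one. Going by these compounds, the step that would isolate the second methoxy cannot be read, as both ends of it are limits, so whether that added group changes the activity at all remains unknown.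

The compounds shown do not tell how far above the limit compound 3 and compound 4 lie, nor whether the two differ from each other. They also leave open how a hydroxyl or an amine would behave in place of methoxy on an aromatic carbon, and whether a longer chain joining the phenyl ring to the nitrogen would alter the number seen for compound 1.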